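Returning from phenyl to cyclohexyl with an undefined stereocentre

A few compounds are considered here, and "the series" means these few. Any claim that something is new, unique, unknown or untested is made for them only; others in the source may bear on it.

Compound 2 `Cc1nc(N)sc1CCCNC(=N)NC(=O)C[C@H](C)c1ccccc1` gives 39.8 nM in a functional assay on cardiac atrium for agonist activity at histamine H2 receptor (Cavia porcellus) (on this read-out lower numbers stand for an effect already at smaller amounts and higher numbers for an effect only at larger amounts of compound), the lower of the two numbers measured; compound 1 `Cc1nc(N)sc1CCCNC(=N)NC(=O)C[C@H](C)C1CCCCC1` gives 91.2 nM. Compound 3 `Cc1nc(N)sc1CCCNC(=N)NC(=O)CC(C)C1CCCCC1` differs from compound 2 by 1-cyclohexylethyl in place of 1-phenylethyl on a saturated chain carbon bound to a carbonyl carbon, the defined stereocentre being lost. Within the data shown here, the one measured step that bears on this is a 2.3-fold lower number from compound 1 to compound 2 (0.36 log units; beyond the scatter), which runs the opposite way. Reversing it, the estimate for compound 3 is a 2.8-fold higher number from compound 2 to compound 3 (0.44 log units; beyond the scatter), a higher number close to that of compound 1. Compound 3 is therefore expected to give 110 nM in this assay, in the range 50 nM to 300 nM.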

Compound 3, half-maximal effective concentration: 69.2 nM
Compound 3: middle estimate off by 1.6-fold (0.20 log units), on the high side, within the range that was stated.
By their numbers in this assay, from the lowest: compounds 2, 3 and 1 (each within the scatter of the next, the first and the last beyond it).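

Read with the stereocentre undefined, 1-cyclohexylethyl in place of 1-phenylethyl gives a 1.7-fold higher number from compound 2 to compound 3 (0.24 log units; within the scatter) and so does not separate the two, unlike the step between the compounds with a defined configuration. Compound 1 and compound 3 also stay together, with a 1.3-fold lower number from compound 1 to compound 3 (0.12 log units; within the scatter) and only one difference to point to: the fact that one of compounds 1 and 3 is drawn with a defined configuration and the other without, at the place where they differ. The gap between the two ring types therefore rests on compound 1 and compound 2 alone.

As far as these compounds go, the effect of the opposite configuration at this carbon remains open. So does that of a hydroxyl or an amine on the cyclohexyl ring.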